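The source may report more compounds than this note shows. Statements on the series, on what has been measured and on what is new or still open speak of the compounds shown alone.

Compound 1 `COc1cccc(-c2nc3cccc(-c4cc(OC)c(OC)c(OC)c4)c3o2)c1` is the starting point of this comparison. In a functional assay on NCI-H460 cells (Homo sapiens) for antiproliferative activity, read by MTT assay, with a stated time of 48 h (a higher number here means a weaker inhibitor, a lower number a stronger inhibitor), compound 1 gives > 25000 nM, which is a limit of the assay rather than a measured number. Compound 1 therefore sits at the limit of > 25000 nM in this assay, at which 1 of the 3 values shown sits, and its true strength is not known beyond that. Two related compounds are measured. Compound 2 `COc1cc(-c2cccc3nc(-c4cccc(F)c4)oc23)cc(OC)c1OC` gives 3300 nM in this assay, and compound 3 `COc1cc(-c2cccc3nc(-c4ccc(N)cc4)oc23)cc(OC)c1OC` gives 310 nM. The measured steps are an at least 7.5-fold lower number from compound 1 to compound 2 (0.87 log units; beyond the scatter), an at least 80-fold lower number from compound 1 to compound 3 (1.90 log units; beyond the scatter) and an 11-fold lower number from compound 2 to compound 3 (1.03 log units; beyond the scatter).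

Compound 4 `COc1cc(-c2cccc3nc(-c4ccc5cc[nH]c5c4)oc23)cc(OC)c1OC` is not yet measured. It differs from compound 1 in one place: 1H-indol-6-yl in place of 3-methoxyphenyl on an aromatic carbon. The two steps that start from compound 1 both bear on this, since both replace the 3-methoxyphenyl group; the step to compound 3 is closest in kind, as 4-aminophenyl and 1H-indol-6-yl each bring one hydrogen-bond donor and no hydrogen-bond acceptor. Both steps lowered the number, one modestly and one largely, so a lower number for compound 4 is expected, most likely of a size near the step to compound 3.

Compound 4 is therefore expected to give about 450 nM, with a range from 100 nM to 3000 nM. This estimate means an expected at least 55-fold lower number from compound 1 to compound 4 (1.74 log units; beyond the scatter).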

Compound 4, half-maximal inhibitory concentration: 24 nM
Compound 4: middle estimate off by 19-fold (1.27 log units), on the high side; measured number below the stated range.
By their numbers in this assay, from the lowest: compound 4; then compound 3; then compound 2. At a limit, above all of these: compound 1.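

At the aromatic carbon of the five-membered ring that carries the changing group, the two-ring 1H-indol-6-yl gives the lowest number of the groups shown in this assay, and each step to it is large and beyond the scatter (a 13-fold lower number from compound 3 to compound 4 (1.11 log units; beyond the scatter); a 140-fold lower number from compound 2 to compound 4 (2.14 log units; beyond the scatter); an at least 1000-fold lower number from compound 1 to compound 4 (3.01 log units; beyond the scatter)). Having a hydrogen-bond donor on this group therefore does not by itself set the level, since 4-aminophenyl in compound 3 also carries one and still gives a clearly higher number than 1H-indol-6-yl in compound 4. The step from compound 1 is only a minimum, because compound 1 stands at a limit of the assay and not at a measured number: the limit of > 25000 nM in this assay, at which 1 of the 4 values shown sits.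

The compounds shown leave open whether the indole's ring hydrogen on nitrogen is needed, which an indole with a methyl group on that nitrogen would test, or whether a related two-ring group such as benzofuran-6-yl, which has oxygen in place of that nitrogen, would do as well. They also leave open how a carboxylic acid or a longer chain on the phenyl ring would behave at this position.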